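Cytotoxicity of Three Quinolone Esters and an Untested Fourth

The compounds below may be only part of what the source reports. "The series", "measured", "known", "first", "only" and "open" are said of these compounds alone.

Compound 1 `CCOC(=O)c1c(-c2cccc(OC)c2)[nH]c2cc(OC)ccc2c1=O`, compound 2 `CCOC(=O)c1c(-c2cccc(OC)c2)[nH]c2cc(OC(F)(F)F)ccc2c1=O` and compound 3 `CCOC(=O)c1c(-c2cccc(OC)c2)[nH]c2cc(C(F)(F)F)ccc2c1=O` were tested in an ADME assay on BJ cells (Homo sapiens) for cytotoxicity, read by luminescence, with a stated time of 72 h; on this read-out lower numbers stand for an effect already at smaller amounts and higher numbers for an effect only at larger amounts of compound. In this assay compound 1 gives only a limit, > 21500 nM. Compound 2 likewise reaches only a limit, > 21500 nM. Compound 3 also stops at a limit, > 21500 nM. Compound 2 differs from compound 1 by trifluoromethyl in place of methyl on an oxygen on an aromatic ring, and a step that the two limits leave unreadable from compound 1 to compound 2. Compound 3 differs from compound 1 by trifluoromethyl in place of methoxy on an aromatic carbon. Compound 4 `CCOC(=O)c1c(-c2cccc(OC(F)(F)F)c2)[nH]c2cc(C(F)(F)F)ccc2c1=O` differs from compound 3 by trifluoromethyl in place of methyl on an oxygen on an aromatic ring, the same change as from compound 1 to compound 2. Since (the limit of > 21500 nM in this assay, at which 3 of the 3 values shown sit), a step that the limit leaves unreadable from compound 3 to compound 4 is expected, and the value for compound 4 in this assay is estimated at 30000 nM, most likely again reported only as a limit.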

Compound 4, half-maximal effective concentration: > 21500 nM
Compound 4: only a limit was reported; the forecaster's own chance of this, stated with the estimate: 85%; the middle value does not contradict the limit.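

No step from compound 3 to compound 4 can be read in this assay, because both compounds stop at a limit: the limit of > 21500 nM in this assay, at which 4 of the 4 values shown sit.

The compounds shown leave open at what concentration any of the four would produce a half-maximal effect.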